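From 4-Chlorophenyl to 3-Chlorophenyl: Compound 1 to Compound 4

The source may report more compounds than this note shows. Statements on the series, on what has been measured and on what is new or still open speak of the compounds shown alone.

Compound 1 `CC1=CC[C@H](C(C)C)c2cc(C)c(OC(=O)c3ccc(Cl)cc3)cc21` carries a 4-chlorophenyl on a carbonyl carbon of the shared core. In a functional assay on U-251 cells (Homo sapiens) for antiproliferative activity, read by sulforhodamine B assay, with a stated time of 48 h, tested at 50 uM (a higher number here means more inhibition at the concentration tested (going by the name of the read-out), a lower number less inhibition), compound 1 gives 25.6%, the second highest of three numbers: compound 3 `Cc1cc2c(C(C)C)ccc(C)c2cc1OC(=O)c1ccc(C(F)(F)F)cc1` gives 16.5%, within the scatter of compound 1, while compound 2 `COc1ccc(C(=O)Oc2cc3c(C)ccc(C(C)C)c3cc2C)cc1` gives 42.6%, beyond it. Among the compounds with values here, the only step between measured compounds is a number 26.1 percentage points lower from compound 2 to compound 3 (beyond the scatter), which exchanges one group for another of a different kind, so it bears only loosely on the present change. Compound 4 `CC1=CC[C@H](C(C)C)c2cc(C)c(OC(=O)c3cccc(Cl)c3)cc21` differs from compound 1 by 3-chlorophenyl in place of 4-chlorophenyl on a carbonyl carbon. Within the data shown here, no measured pair tests such a change, so compound 4 is expected to stay within the scatter of compound 1, with a number 0.4 percentage points higher from compound 1 to compound 4 (within the scatter). Compound 4 is estimated at 26%, between 10% and 44%.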

Compound 4, a percentage reported as inhibition, at one concentration (the size of the read-out at that concentration, not a potency): 0.9%
Compound 4: the middle estimate sits 25.1 percentage points above what was measured; measured number outside the range, below it.
By their numbers in this assay, from the lowest: compound 4; then compounds 3 and 1 (each within the scatter of the next); then compound 2.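

In this assay the change to 3-chlorophenyl from 4-chlorophenyl, with the same atoms and no group added or lost, gives a number 24.7 percentage points lower from compound 1 to compound 4 (beyond the scatter) and so shows that the place of the chlorine on this phenyl alone can shift the read-out beyond the scatter. The earlier step exchanged one group for another and could not show this. Nothing measured here accounts for the loss of inhibition. Still open, as far as these compounds go, is whether the methoxy and trifluoromethyl groups would respond to the same shift on the phenyl, and how an amine or a carboxylic acid in place of the chlorine would read.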